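The source may report more compounds than this note shows. Statements on the series, on what has been measured and on what is new or still open speak of the compounds shown alone.

In a functional assay on DU-145 cells (Homo sapiens) for inhibition, read by trypan blue exclusion, with a stated time of 96 h (a lower number here means a stronger inhibitor of growth, a higher number a weaker inhibitor of growth), compound 1 (`O=C(O)c1ccc(C(=O)/C(=C\c2ccc(Br)c([N+](=O)[O-])c2)SCc2ccccc2Cl)cc1`) gives 1000 nM. It stands level with compound 2 (`O=C(O)c1ccc(C(=O)/C(=C\c2ccc(Br)c([N+](=O)[O-])c2)SCc2ccc(F)cc2)cc1`), at 1000 nM, and with compound 3 (`O=C(O)c1ccc(C(=O)/C(=C\c2ccc(Br)c([N+](=O)[O-])c2)SCc2ccc(Br)cc2)cc1`), at 1000 nM. Compound 4 (`O=C(O)c1ccc(C(=O)/C(=C\c2ccc(F)c([N+](=O)[O-])c2)SCc2ccccc2Cl)cc1`) has not yet been measured. It differs from compound 1 in one place, fluoro in place of bromo on an aromatic carbon, where the 4-bromo-3-nitrophenyl group becomes 4-fluoro-3-nitrophenyl. Among the compounds with values here, no measured step touches this group. The nearest evidence is no change at the digits printed from compound 2 to compound 3 (within the scatter), which exchanges the same two halogens in the opposite direction at a different place in the molecule. The steps of no change at the digits printed from compound 1 to compound 2 (within the scatter) and no change at the digits printed from compound 1 to compound 3 (within the scatter) also alter only the aryl group on the chain carbon bound to sulfur. These three steps show no movement, but they only indirectly inform the new change, so no step beyond the scatter is expected in this assay, and no direction is favoured. The expected step is no change at the digits printed from compound 1 to compound 4 (within the scatter). For compound 4 the estimated value is 1000 nM, with an expected range from 450 nM to 2200 nM.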

Compound 4, concentration for 50% growth inhibition: 1000 nM
Compound 4: middle estimate and measured number agree at the digits printed; the range from low to high includes it.
By their numbers in this assay, from the lowest: compounds 1, 2, 3 and 4 (each within the scatter of the next).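

Compounds 1, 2 and 3 all carry the 4-bromo-3-nitrophenyl group, so they could say nothing about this aromatic carbon, ortho to a nitro group; in this assay, fluoro in place of bromo here gives no change at the digits printed from compound 1 to compound 4 (within the scatter). The change of the aryl group on the chain carbon bound to sulfur is therefore no longer the only variation tested, and this second place in the molecule also tolerates both halogens. The exchange between these two halogens now reads the same at both places: the same change on two cores in this assay, no change at the digits printed (within the scatter) from compound 2 to compound 3 and no change at the digits printed (within the scatter) from compound 4 to compound 1, 1.0-fold (0.00 log units) apart, within the scatter of two such steps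

From the compounds shown here alone, only bromo and fluoro have been seen on this carbon, so it remains open whether an amine or a methoxy group there would stay level in this assay. Going by these compounds, it is also open whether a nitrile in place of the nitro group, or an amide in place of the carboxylic acid, would move the value at all.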